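Notes on the step from compound 3 to compound 4

The compounds below may be only part of what the source reports. "The series", "measured", "known", "first", "only" and "open" are said of these compounds alone.

In a functional assay on the whole organism for agonist activity, with Rattus norvegicus as the target (a higher number here means that more compound is needed for the effect, a lower number that less compound is needed), compound 3 `c1ccc2c(c1)CC(CCN1CCN(c3cccc4c3OCCO4)CC1)C2` gives 10 mg/kg, the lowest of the two numbers shown; its nearest neighbour is compound 1 `Clc1cccc2c1CC2CCN1CCN(c2cccc3c2OCCO3)CC1` at 40 mg/kg, and the step of a 4.0-fold lower number from compound 1 to compound 3 (0.60 log units; beyond the scatter) lies beyond the scatter. Compound 2 `C1=C(CCN2CCN(c3cccc4c3OCCO4)CC2)c2ccccc2C1` returned only a limit, > 2.5 mg/kg. Because of that limit the steps a step that the limit leaves unreadable from compound 1 to compound 2 and a step that the limit leaves unreadable from compound 2 to compound 3 cannot be read. Compound 4 `C1=C(CCN2CCN(c3cccc4c3OCCO4)CC2)Cc2ccccc21` differs from compound 3 by a group of 9 heavy atoms (9 carbon; one five-membered non-aromatic ring of carbon only, one six-membered aromatic ring of carbon only) in place of a group of 9 heavy atoms (9 carbon; one five-membered non-aromatic ring of carbon only, one six-membered aromatic ring of carbon only), on a saturated chain carbon, two bonds along the chain from an amine nitrogen in a ring. Within the data shown here, no measured step shares this change; the steps at the same place exchange the whole group, and the single readable one, a 4.0-fold lower number from compound 1 to compound 3 (0.60 log units; beyond the scatter), is modest. For compound 4 the expected step of no change at the digits printed from compound 3 to compound 4 (within the scatter) is therefore small, in either direction, with wide uncertainty. Compound 4 is estimated at 10 mg/kg in this assay, within 3 mg/kg to 40 mg/kg.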

Compound 4, minimum effective dose: 10 mg/kg
Compound 4: middle estimate and measured number agree at the digits printed; the range from low to high includes it.
By their numbers in this assay, from the lowest: compounds 3 and 4 (each within the scatter of the next); then compound 1.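

In this assay, the group with one double bond outside aromatic rings, entering in place of 2,3-dihydro-1H-inden-2-yl, gives no change at the digits printed from compound 3 to compound 4 (within the scatter). Among these compounds, this is the first readable step at this place that keeps the ring count and the heavy-atom count of the group, and the double bond leaves the number unmoved. The gap to the group with the four-membered ring and chlorine persists, with a 4.0-fold lower number from compound 1 to compound 4 (0.60 log units; beyond the scatter).

Compound 2 carries a limit, not a number, so its steps to the other compounds cannot be read: the limit of > 2.5 mg/kg in this assay, at which 1 of the 4 values shown sits. Still open, from the compounds shown here alone, is how a methoxy-bearing group or a longer chain would read at this place.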